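A few compounds are considered here, and "the series" means these few. Any claim that something is new, unique, unknown or untested is made for them only; others in the source may bear on it.

In a functional assay on HT-29 cells (Homo sapiens) for inhibition, read by MTT assay, with a stated time of 120 h (on this read-out higher numbers stand for weaker inhibition and lower numbers for stronger inhibition), compound 2 `CNC(=O)/C=C/c1ccc(NC(=O)Nc2ccc(Cl)c(C(F)(F)F)c2)cc1` gives 11700 nM and sits at the upper of the two values measured, yet the gap to compound 1 `CC(NC(=O)c1cccc(-c2ccc(NC(=O)Nc3ccc(Cl)c(C(F)(F)F)c3)cc2)c1)c1ccccc1`, which gives 6320 nM, lies within the scatter. Compound 3 `CNC(=O)c1cccc(-c2ccc(NC(=O)Nc3ccc(Cl)c(C(F)(F)F)c3)cc2)c1` differs from compound 2 by 3-(methylcarbamoyl)phenyl in place of 2-(methylcarbamoyl)ethenyl on an aromatic carbon, leaving it to share with compound 1 everything except the substituent on the amide nitrogen. Among the measured compounds shown here, no measured step covers this change, so the expectation rests on compound 1 alone: a small move toward lower numbers, not beyond the scatter, is expected because compound 1 gives 6320 nM with the same ring arrangement in place. The expected step of a 1.8-fold lower number from compound 2 to compound 3 (0.26 log units; within the scatter) is accordingly modest. Compound 3 is therefore estimated at 6500 nM in this assay, with a range from 2500 nM to 16000 nM.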

Compound 3, half-maximal inhibitory concentration: 29300 nM
Compound 3: the middle estimate sits 4.5-fold (0.65 log units) below what was measured; the whole stated range lies below it.
By their numbers in this assay, from the lowest: compounds 1 and 2 (each within the scatter of the next); then compound 3.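

In this assay the change from 2-(methylcarbamoyl)ethenyl to 3-(methylcarbamoyl)phenyl at this aromatic carbon brings a 2.5-fold higher number from compound 2 to compound 3 (0.40 log units; beyond the scatter) so this larger group does not by itself give the lower number of compound 1. With that group held fixed, methyl in place of 1-phenylethyl on the amide nitrogen brings a 4.6-fold higher number from compound 1 to compound 3 (0.67 log units; beyond the scatter) and so the substituent there clearly changes the read-out. Nothing available explains either step. Still open, as far as these compounds go, is whether a benzyl group or a longer chain on that nitrogen would keep the number low, and whether an amine or a carboxylic acid would be tolerated there.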